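Swapping an Ethoxy for an Aminoethyl Chain

The compounds below may be only part of what the source reports. "The series", "measured", "known", "first", "only" and "open" are said of these compounds alone.

Compound 1 `CCNC(=O)Nc1cccc2c1CN(C)CC2c1ccccc1`: 54 mg/kg
Compound 2 `CCOC(=O)Nc1cccc2c1CN(C)CC2c1ccccc1`: about 4 mg/kg
Compound 3 `CCOC(=O)Nc1cccc2c1CN(C)CC2c1ccc(F)cc1`: 3.3 mg/kg

All three measured compounds share the same core and were tested in a functional assay on the whole organism for inhibition, with Mus musculus as the target; on this read-out lower numbers stand for an effect already at smaller amounts and higher numbers for an effect only at larger amounts of compound. Compound 2 gives about 4 mg/kg there, which is the second highest of the three numbers. Compound 3, which gives 3.3 mg/kg, sits within the scatter of compound 2 (a 1.2-fold lower number from compound 2 to compound 3 (0.08 log units; within the scatter)). Compound 1, which gives 54 mg/kg, lies far beyond the scatter: a 14-fold lower number from compound 1 to compound 2 (1.13 log units; beyond the scatter).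

The next compound, compound 4 `CCNCCC(=O)Nc1cccc2c1CN(C)CC2c1ccccc1`, has not yet been measured. It differs from compound 2 in one place: 2-(ethylamino)ethyl in place of ethoxy on a carbonyl carbon.

For the measured compounds named here, the one measured step that bears on this change is the step from compound 1 to compound 2, where an ethoxy replaced an ethylamino on the same carbonyl carbon and produced a large step, a 14-fold lower number from compound 1 to compound 2 (1.13 log units; beyond the scatter). Compound 4 does not return to the ethylamino of compound 1, but it again puts a nitrogen-bearing group in place of the ethoxy, so a step back toward higher numbers in this assay seems the more likely outcome, though its size is uncertain. Compound 4 is therefore expected to give about 20 mg/kg, within 5 mg/kg to 80 mg/kg, which would be a step of a 5.0-fold higher number from compound 2 to compound 4 (0.70 log units; beyond the scatter).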

Compound 4, dose for half-maximal effect: > 160 mg/kg
Compound 4 gave a limit, no number (the forecaster's own chance of this, stated with the estimate: 10%); middle value at least 8.0-fold (0.90 log units) from the limit.
By their numbers in this assay, from the lowest: compounds 3 and 2 (each within the scatter of the next); then compound 1. At a limit, above all of these: compound 4.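

Compound 4 gives no number in this assay, only a limit: the limit of > 160 mg/kg in this assay, at which 1 of the 4 values shown sits. Putting 2-(ethylamino)ethyl in place of ethoxy on this carbonyl carbon gives an at least 40-fold higher number from compound 2 to compound 4 (1.60 log units; beyond the scatter), a large step, which shows that this position does not accept every longer chain, at least not one carrying a nitrogen further out. Set against the ethylamino group on the same carbonyl carbon, the chain gives an at least 2.9-fold higher number from compound 1 to compound 4 (0.47 log units; beyond the scatter), so among the three groups shown here ethoxy goes with the lowest numbers, ethylamino with a higher one and 2-(ethylamino)ethyl with the limit, and moving the nitrogen away from the carbonyl carbon brings back none of what ethoxy gave.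

The compounds shown do not separate the length of the chain from its nitrogen, since an all-carbon chain such as butyl, or a longer ether such as 2-ethoxyethyl, would be needed to tell the two apart. On these data alone, how far compound 4 lies past its limit also stays unknown, as does the effect of the fluoro group of compound 3 on a compound with this chain.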